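Pyrazole chalcones: aryl ketone variation in the lung cell assay

The source may hold more compounds than are shown below. What is called first, only, known or untested is meant among the compounds shown, and "the series" means these compounds.

Measured so far:
compound 1 `COc1cc(-c2cc(/C=C/C(=O)c3ccc(Cl)c(Cl)c3)[nH]n2)cc(OC)c1OC` — 6970 nM
compound 2 `COc1ccc(C(=O)/C=C/c2cc(-c3cc(OC)c(OC)c(OC)c3)n[nH]2)cc1OC` — 825 nM
compound 3 `COc1ccc(C(=O)/C=C/c2cc(-c3cc(OC)c(OC)c(OC)c3)n[nH]2)cc1` — 6970 nM

In a functional assay on NCI-H522 cells (Homo sapiens) for inhibition, read by sulforhodamine B assay, with a stated time of 48 h (on this read-out lower numbers stand for higher toxicity in this test and higher numbers for lower toxicity in this test), compound 3 stands level with compound 1 at the digits printed, the two together giving the highest numbers of the three; compound 2 is the furthest off, as an 8.4-fold higher number from compound 2 to compound 3 (0.93 log units; beyond the scatter) shows. The step to compound 4 `COc1cc(-c2cc(/C=C/C(=O)c3ccc(F)c(F)c3)[nH]n2)cc(OC)c1OC` is 3,4-difluorophenyl in place of 4-methoxyphenyl on a carbonyl carbon. Going by the values given here, two measured steps bear on it. The ring on the carbonyl carbon has already been varied at the same place: no change at the digits printed from compound 1 to compound 3 (within the scatter), so a 3,4-dichlorophenyl and a 4-methoxyphenyl behave alike here, and an 8.4-fold lower number from compound 1 to compound 2 (0.93 log units; beyond the scatter), where the extra methoxy is what sets compound 2 apart. Compound 4 carries a 3,4-difluorophenyl, a ring pattern closer to that of compound 1 than to that of compound 2, so the expected step is none beyond the scatter: a 1.0-fold higher number from compound 3 to compound 4 (0.00 log units; within the scatter). Compound 4 is therefore estimated at 7000 nM in this assay, with a range from 2500 nM to 20000 nM.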

Compound 4, concentration lethal to 50% of the cells: 65200 nM
Estimate against measurement, compound 4: 9.3-fold (0.97 log units) below; the whole stated range lies below it.
By their numbers in this assay, from the lowest: compound 2; then compounds 1 and 3 (each within the scatter of the next); then compound 4.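

In this assay the ring on the carbonyl carbon can shift the number upward as well as downward: the 3,4-difluorophenyl gives a 9.4-fold higher number from compound 3 to compound 4 (0.97 log units; beyond the scatter) and also a 9.4-fold higher number from compound 1 to compound 4 (0.97 log units; beyond the scatter) so 3,4-dichlorophenyl and 3,4-difluorophenyl do not behave alike here, although both rings carry two halogen atoms. Against the 3,4-dimethoxyphenyl the gap widens to a 79-fold higher number from compound 2 to compound 4 (1.90 log units; beyond the scatter) and this large step sets the span of the ring change so far, with compound 4 holding the highest number of the four and its steps to all the others beyond the scatter. Nothing at hand bears on why replacing chlorine with fluorine separates these two compounds.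

Still open, going by these compounds, is whether a ring bearing an amine or a carboxylic acid on the carbonyl carbon would fall nearer compound 2 or compound 4. Also open, on these data alone, is whether a single methoxy and a single fluorine would each hold the number of their disubstituted counterparts.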